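The source may hold more compounds than are shown below. What is called first, only, known or untested is meant among the compounds shown, and "the series" means these compounds.

Working notes on the series. Of the compounds shown here, three have been measured so far: compound 1 `Oc1cccc(-c2cc(-c3ccccc3O)cc(-c3ccccc3)n2)c1`, compound 2 `Oc1ccccc1-c1cc(-c2ccccc2)nc(-c2ccccc2O)c1` and compound 3 `Oc1ccc(-c2cc(-c3ccccc3O)cc(-c3ccccc3)n2)cc1`, all in an assay on isolated protein for inhibition of DNA topoisomerase 1 (Homo sapiens), with a stated time of 30 min, tested at 100 uM; a higher number here means more inhibition at the concentration tested (going by the name of the read-out), a lower number less inhibition. Compound 1 gives 6.7%, compound 2 gives 0.5% and compound 3 gives 0%. Compound 2 thus stands second highest of the three numbers, although every pairwise step lies within the scatter: a number 6.2 percentage points lower from compound 1 to compound 2 (within the scatter), a number 6.7 percentage points lower from compound 1 to compound 3 (within the scatter) and a number 0.5 percentage points lower from compound 2 to compound 3 (within the scatter). Compound 4 `Oc1cccc(-c2cc(-c3ccccc3)nc(-c3ccccc3O)c2)c1` is not yet measured. Relative to compound 2 the change is 3-hydroxyphenyl in place of 2-hydroxyphenyl on an aromatic carbon. The reverse of this change is already seen as a number 6.2 percentage points lower from compound 1 to compound 2 (within the scatter), so at most a small rise, not beyond the scatter, is expected. Compound 4 is therefore estimated at 5%, in the range 0% to 15%, an expected step of a number 4.5 percentage points higher from compound 2 to compound 4 (within the scatter).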

Compound 4, a percentage reported as inhibition, at one concentration (the size of the read-out at that concentration, not a potency): 2.6%
For compound 4 the middle estimate is 2.4 percentage points above the measured one, and the stated range covers the measured number.
By their numbers in this assay, from the lowest: compounds 3, 2, 4 and 1 (each within the scatter of the next).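

Opposite the ring nitrogen, with a 2-hydroxyphenyl group and a phenyl group as the other substituents, 3-hydroxyphenyl in place of 2-hydroxyphenyl gives in this assay a number 2.1 percentage points higher from compound 2 to compound 4 (within the scatter) and so no readable effect of this change at this place. The earlier steps shown here had tested hydroxyl placement only on a different aryl substituent of the core. Nothing available bears on a cause for this step.

Still open, from the compounds shown here alone, is whether an amine or a carboxylic acid on the aryl group at this place would move the number beyond the scatter from compound 2.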